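Amide side chain exchange: compound 3 to compound 4

The compounds below may be only part of what the source reports. "The series", "measured", "known", "first", "only" and "open" are said of these compounds alone.

In a functional assay on PC-3 cells (Homo sapiens) for antiproliferative activity, read by MTT assay, with a stated time of 24 h (a lower number here means a stronger inhibitor, a higher number a weaker inhibitor), three compounds sharing one core have been read. Compound 1 `CCn1c(C(=O)N[C@@H](C)C(=O)OC)ccc1C(CC)(CC)c1ccc(OCS(=O)(=O)c2ccccc2)c(C)c1` gives > 50000 nM, which is a limit of the assay and not a number. Compound 2 `CCn1c(C(=O)N[C@H](C)C(=O)OC)ccc1C(CC)(CC)c1ccc(OCS(=O)(=O)c2ccccc2)c(C)c1` gives > 50000 nM, again a limit and not a number. The series is bounded by the limit of > 50000 nM in this assay, at which 2 of the 3 values shown sit. The pair shows a step that the two limits leave unreadable from compound 1 to compound 2, and the only structural contrast is the fact that compounds 1 and 2 differ only in the configuration as drawn.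

Going by the values given here, compound 3 `CCn1c(C(=O)NCCN)ccc1C(CC)(CC)c1ccc(OCS(=O)(=O)c2ccccc2)c(C)c1` gives 6890 nM, the only true number. The exchange of 1-(methoxycarbonyl)ethyl for 2-aminoethyl gives an at least 7.2-fold lower number from compound 1 to compound 3 (0.86 log units; beyond the scatter) and likewise an at least 7.2-fold lower number from compound 2 to compound 3 (0.86 log units; beyond the scatter).

Compound 4 `CCn1c(C(=O)N[C@@H](C)CO)ccc1C(CC)(CC)c1ccc(OCS(=O)(=O)c2ccccc2)c(C)c1` carries a new change, 1-(hydroxymethyl)ethyl in place of 2-aminoethyl on an amide-type nitrogen. Among the compounds with values here, no measured step covers this exchange directly. The nearest evidence is the pair of steps above, an at least 7.2-fold lower number from compound 1 to compound 3 (0.86 log units; beyond the scatter) and an at least 7.2-fold lower number from compound 2 to compound 3 (0.86 log units; beyond the scatter), in which 2-aminoethyl enters, whereas here it leaves. Part of that gain is therefore expected to be lost, with a higher number in this assay and a real chance of reaching the limit. The expected change is a 3.6-fold higher number from compound 3 to compound 4 (0.56 log units; beyond the scatter). Compound 4 is estimated at 25000 nM, with an expected range of 9000 nM to 50000 nM.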

Compound 4, half-maximal inhibitory concentration: 9520 nM
For compound 4 the middle estimate is 2.6-fold (0.42 log units) above the measured one, within the range that was stated.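

In this assay, the side chain on the amide-type nitrogen no longer depends on 2-aminoethyl for a readable value: a 1.4-fold higher number from compound 3 to compound 4 (0.14 log units; within the scatter), so 1-(hydroxymethyl)ethyl and 2-aminoethyl cannot be told apart at this place. The earlier compounds shown here could not show whether the amine itself was required to come off the limit, and the chain without it does so too, with an at least 5.2-fold lower number from compound 2 to compound 4 (0.72 log units; beyond the scatter) and an at least 5.2-fold lower number from compound 1 to compound 4 (0.72 log units; beyond the scatter), the exchange here being a hydroxymethyl in place of a methoxycarbonyl. Both of these steps start from a limit and not from a number, so their true size stays unfixed: the limit of > 50000 nM in this assay, at which 2 of the 4 values shown sit.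

Whether the configuration of the stereocentre in 1-(hydroxymethyl)ethyl matters remains open, and the one configuration pair shown cannot be read: the fact that compounds 1 and 2 differ only in the configuration as drawn. Also open, as far as these compounds go, is how a carboxylic acid, a longer chain such as 3-aminopropyl, or a terminal dimethylamino group would read in this assay, and whether any of them would move the number beyond the scatter from compound 3 and compound 4.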